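Swapping the group on the ring nitrogen: compound 4

The compounds below may be only part of what the source reports. "The series", "measured", "known", "first", "only" and "open" are said of these compounds alone.

Compound 1 `Cc1ccccc1-c1nn(-c2ccc(Cl)cc2)cc1CNCCN1CCN(C)CC1` gives 17000 nM in an ADME assay on Huh-7 cells (Homo sapiens) for cytotoxicity; a higher number here means that more compound is tolerated, a lower number that less compound is tolerated.
Compound 2 `Cc1ccccc1-c1nn(Cc2ccc(F)cc2)cc1CNCCN1CCN(C)CC1` gives > 20000 nM in this assay, which is a limit of the assay and not a number.
Compound 3 `Cc1ccccc1-c1nn(-c2ccc(F)cc2F)cc1CNCCN1CCN(C)CC1` gives > 20000 nM in this assay, again a limit of the assay and not a number.

Compound 3 therefore stands at the limit of > 20000 nM in this assay, at which 2 of the 3 values shown sit, so for it only a limit, not a measured number, is known. The change to compound 4 `Cc1ccccc1-c1nn(-c2cccc(C(F)(F)F)c2)cc1CNCCN1CCN(C)CC1` is 3-(trifluoromethyl)phenyl in place of 2,4-difluorophenyl on an aromatic nitrogen. Two measured steps change the group on the same aromatic nitrogen and end at compound 3: an at least 1.1-fold higher number from compound 1 to compound 3 (0.07 log units; that floor lies within the scatter) and a step that the two limits leave unreadable from compound 2 to compound 3. The remaining step, an at least 1.1-fold higher number from compound 1 to compound 2 (0.07 log units; that floor lies within the scatter), also stays within the scatter. None of these swaps on that nitrogen gave a readable shift in this assay, and the same is expected for the trifluoromethyl-bearing ring. The step of a number no higher from compound 3 to compound 4 (the limit leaves the size open) is expected to stay within the scatter. Compound 4 is estimated to give 20000 nM, with a range from 9000 nM to 45000 nM, and with a real chance that this assay once more reports only a limit.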

Compound 4, half-maximal cytotoxic concentration: 18000 nM
Estimate against measurement, compound 4: 1.1-fold (0.05 log units) above, within the range that was stated.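

For the compounds shown here, with 3-(trifluoromethyl)phenyl on the aromatic nitrogen, this assay returns a number rather than a limit, giving this position a second measured value and a first direct comparison between two numbers: a 1.1-fold higher number from compound 1 to compound 4 (0.02 log units; within the scatter). Against the other two groups, the steps are an at least 1.1-fold lower number from compound 3 to compound 4 (0.04 log units; that floor lies within the scatter) and an at least 1.1-fold lower number from compound 2 to compound 4 (0.04 log units; that floor lies within the scatter), so the larger trifluoromethyl-bearing ring adds no step shown to lie beyond the scatter, although these two floors leave the true sizes open. Compound 2 and compound 3 are known only through a limit of the assay, not through numbers: the limit of > 20000 nM in this assay, at which 2 of the 4 values shown sit.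

Going by these compounds, whether a more different group on this nitrogen, such as a phenyl ring carrying an amine or a carboxylic acid, would move the number beyond the scatter stays open. So does whether a change elsewhere on the shared core, such as replacing the 2-methylphenyl group, would do so.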